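This account rests on a few compounds, and the source may have more. Where it says the series, first, only, none or still open, it means among the compounds named here.

Among the measured compounds shown here, in a physicochemical assay for lipophilicity, read by HPLC, in phosphate buffer, measured as octanol-water partition, at pH 7.4, tested at 100 uM (on this read-out lower numbers stand for lower lipophilicity and higher numbers for higher lipophilicity), compound 1 (`Cc1ccc(-c2cccc(CNc3ccc(OCC(=O)O)c(F)c3)c2)c(Cl)c1`) gives 3.24 and compound 2 (`CCOc1ccc(-c2cccc(CNc3ccc(OCC(=O)O)c(F)c3)c2)c(C)c1`) gives 2.83 as the lower of the two numbers so far. For the measured compounds named here, the only measured step of a number 0.41 log units lower from compound 1 to compound 2 (beyond the scatter) is modest and of a different kind, and no measured step adds a hydroxy. The change to compound 3 (`Cc1cc(OCCO)ccc1-c1cccc(CNc2ccc(OCC(=O)O)c(F)c2)c1`) is hydroxy in place of hydrogen on a saturated chain carbon, two bonds along the chain from an oxygen on an aromatic ring and reads as ethoxy to 2-hydroxyethoxy. With so little direct precedent, a downward step in this assay larger than the one measured is expected, with a number 0.83 log units lower from compound 2 to compound 3 (beyond the scatter) as the estimate. Compound 3 is estimated at 2 with 1.5 to 2.4 as the expected range.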

Compound 3, distribution coefficient: 1.65
The estimate for compound 3 lay 0.35 log units above the measured number; low and high end bracket the measured number.
By their numbers in this assay, from the lowest: compound 3; then compound 2; then compound 1.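

In this assay, the step of a number 1.18 log units lower from compound 2 to compound 3 (beyond the scatter) is large, while the earlier step of a number 0.41 log units lower from compound 1 to compound 2 (beyond the scatter) is modest even though it changes the whole aryl group. A single hydroxy on a saturated chain carbon, two bonds along the chain from an oxygen on an aromatic ring, therefore moves this read-out further than that earlier exchange did. Going by these compounds, whether an amine or a carboxylic acid at the chain end, or a longer chain carrying the hydroxy, would give a similar step stays open. No evidence at hand accounts for the size of this step.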